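The source may report more compounds than this note shows. Statements on the series, on what has been measured and on what is new or still open speak of the compounds shown alone.

Compound 1 `CC1(c2ccc(NC(c3ccncc3)c3nnnn3C(C)(C)C)cc2)NC(=O)c2ccccc2N1` carries a pyridin-4-yl group on the carbon that links the shared core to a tetrazole ring. In an ADME assay on Vero cells (Chlorocebus sabaeus) for cytotoxicity, read by MTT assay, with a stated time of 72 h (on this read-out lower numbers stand for higher toxicity in this test and higher numbers for lower toxicity in this test), compound 1 has no single number, since the result was not determined "not determined" (no result reported). Compound 2 `CCCCNC(c1ccc(C2NC(=O)c3ccccc3N2)cc1)c1nnnn1C(C)(C)C` was likewise left without a result in this assay "not determined" (no result reported). Compound 3 `CC1(c2ccc(NC(c3ccc(Br)cc3)c3nnnn3C3CCCCC3)cc2)NC(=O)c2ccccc2N1` reached only a limit of this assay, reporting > 400000 nM, which is a limit rather than a number. Among the measured compounds shown here, that the limit of > 400000 nM in this assay, at which 1 of the 3 values shown sits, is the only reading among the three, so compound 1 stands with no number of its own beside one limit and one missing entry.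

Compound 4 `CC1(c2ccc(NC(c3ccc(Cl)cc3)c3nnnn3C(C)(C)C)cc2)NC(=O)c2ccccc2N1` differs from compound 1 by 4-chlorophenyl in place of pyridin-4-yl on a saturated chain carbon bound to an aromatic carbon and a nitrogen on an aromatic ring. No measured step between any two of these compounds exists in this assay, so there is no basis for expecting a move beyond the usual scatter in this assay in either direction. Drawing only on the limit seen for compound 3, compound 4 is expected to sit around 400000 nM, with a likely range from 100000 nM to 1000000 nM.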

Compound 4, half-maximal cytotoxic concentration: > 400000 nM
Compound 4 was reported as a limit; the forecaster's own chance of this, stated with the estimate: 70%; the middle value lies on the limit itself.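

Among the compounds shown here, no step from compound 1 to compound 4 can be read. In this assay compound 4 gives > 400000 nM as a limit and not a number. The compounds shown leave open how 4-chlorophenyl in place of pyridin-4-yl changes the half-maximal cytotoxic concentration, as the readings stop at one point: the limit of > 400000 nM in this assay, at which 2 of the 4 values shown sit.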